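The compounds below may be only part of what the source reports. "The series", "measured", "known", "first", "only" and "open" are said of these compounds alone.

In a physicochemical assay for solubility, in phosphate buffer (a higher number here means a more soluble compound, a lower number a less soluble compound), compound 1 `O=C(NO)c1ccc(NC2CCN(c3ccc(Cl)c(Cl)c3)C2=O)cc1` gives < 1 ug/mL, which is a limit of the assay and not a number. This is the limit of < 1 ug/mL in this assay, at which 1 of the 3 values shown sits. The two other measured compounds return numbers: compound 2 `CS(=O)(=O)c1ccc(N2CCC(Nc3ccc(C(=O)NO)cc3)C2=O)cc1` gives 97 ug/mL and compound 3 `O=C(NO)c1ccc(NC2CCN(c3ccc(C(F)(F)F)cc3)C2=O)cc1` gives 43 ug/mL.

Compound 4 `O=C(NO)c1ccc(NC2CCN(Cc3ccccc3)C2=O)cc1` keeps the core of compound 1 and carries benzyl in place of 3,4-dichlorophenyl on an amide-type nitrogen in a ring. For the measured compounds named here, no measured step covers this exchange directly. Going by the values given here, the only measured step is a 2.3-fold lower number from compound 2 to compound 3 (0.35 log units; beyond the scatter), a modest change that swaps trifluoromethyl for methylsulfonyl on an aromatic carbon, so it bears on the present change only loosely. The firmer guide is the contrast between the limit of compound 1 and the measured numbers of the other two compounds. Of those two, compound 3 at 43 ug/mL is the closer reference. On that basis, a rise in this assay is expected, and the size of the rise is uncertain since compound 1 has no exact number. The expected change is an at least 35-fold higher number from compound 1 to compound 4 (1.54 log units; beyond the scatter). Compound 4 is estimated at 35 ug/mL, with an expected range of 6 ug/mL to 130 ug/mL.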

Compound 4, solubility: > 385 ug/mL
Compound 4: no number, only a limit (the forecaster's own chance of this, stated with the estimate: 10%); middle value at least 11-fold (1.04 log units) from the limit.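

In this assay, for the compounds shown here, with the core of compound 1 kept, benzyl in place of 3,4-dichlorophenyl on an amide-type nitrogen in a ring gives an at least 380-fold higher number from compound 1 to compound 4 (2.58 log units; beyond the scatter), which shows that the group at this position can carry a very large change in the reading, whereas the only earlier step, a 2.3-fold lower number from compound 2 to compound 3 (0.35 log units; beyond the scatter), exchanged one group for another on an aromatic carbon. Compound 1 stands at the low end of this step with a limit and not a number: the limit of < 1 ug/mL in this assay, at which 1 of the 4 values shown sits. Compound 4 stands at the high end, also with a limit and not a number, so the full size of the step stays unfixed: the limit of > 385 ug/mL in this assay, at which 1 of the 4 values shown sits.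

The exchange removes the chlorine atoms and also adds a carbon between the nitrogen and the aromatic ring, and the compounds shown do not tell which of these two differences carries the step. Plain phenyl or 3,4-dichlorobenzyl on the same nitrogen would separate them, and a benzyl bearing an amine or a carboxylic acid would show how far the reading at this position can still move.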